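Removing the amide-nitrogen phenyl from a weak antiproliferative

A few compounds are considered here, and "the series" means these few. Any claim that something is new, unique, unknown or untested is made for them only; others in the source may bear on it.

Measured compounds:
- compound 1, `O=C1COc2ccc(-c3cnc(Cl)c(NS(=O)(=O)c4ccc(F)cc4)c3)cc2N1c1ccccc1`: 36900 nM
- compound 2, `O=C1COc2ccc(-c3cnc4ccccc4c3)cc2N1C1CCCCC1`: > 40000 nM

Two compounds share the same fused bicyclic core. Going by the values given here, in a functional assay on A-375 cells (Homo sapiens) for antiproliferative activity, read by MTT assay, with a stated time of 72 h (a higher number here means a weaker inhibitor, a lower number a stronger inhibitor), compound 1 gives 36900 nM, and this is the only actual number among the two results. For compound 2 the assay reports only a limit, > 40000 nM, so no number is known for it. Compound 1 therefore stands as the sole measured point, with the other result sitting at the limit of > 40000 nM in this assay, at which 1 of the 2 values shown sits.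

Compound 3, `O=C1COc2ccc(-c3cnc(Cl)c(NS(=O)(=O)c4ccc(F)cc4)c3)cc2N1`, has not yet been measured. It differs from compound 1 in one place: hydrogen in place of phenyl on an amide-type nitrogen in a ring.

Among the compounds with values here, no measured pair in this set differs in the same way, so the size of this step cannot be read from the data. Because compound 1 already gives 36900 nM, a weak result, compound 3 is expected to remain weak as well, and the step of a 1.1-fold higher number from compound 1 to compound 3 (0.04 log units; within the scatter) is estimated to be small, quite possibly within the scatter. The estimate for compound 3 is 40000 nM, with a range of 12000 nM to 120000 nM.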

Compound 3, half-maximal inhibitory concentration: > 40000 nM
Compound 3: only a limit was reported (the forecaster's own chance of this, stated with the estimate: 50%); the middle value sits exactly at the limit.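

Going by these compounds alone, this is the first comparison in the set between two compounds that differ in only one place. With hydrogen in place of phenyl on the amide-type nitrogen in a ring, this assay shows an at least 1.0-fold higher number from compound 1 to compound 3 (0.03 log units; that floor lies within the scatter). Compound 3 does not reach a readable value with this change, and the true size of the step remains unknown because its result lies at the end of the assay's range: the limit of > 40000 nM in this assay, at which 2 of the 3 values shown sit.

The compounds shown leave open whether another group on this nitrogen, such as a methyl or a longer chain ending in an amine, would give a readable number. They also leave open which parts of compound 1 account for its weak activity.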